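A few compounds are considered here, and "the series" means these few. Any claim that something is new, unique, unknown or untested is made for them only; others in the source may bear on it.

In a functional assay on HCT-116 cells (Homo sapiens) for antiproliferative activity, read by MTT assay, with a stated time of 72 h (on this read-out higher numbers stand for weaker inhibition and lower numbers for stronger inhibition), compound 1 `NC1=NC2(CCSCC2)N(OCCCOc2cccc(Cl)c2)C(N)=N1` gives 1 nM and compound 2 `NC1=NC2(CCOCC2)N(OCCCOc2ccc(Br)cc2)C(N)=N1` gives 320 nM in the same read-out. Compound 1 holds the lower of the two numbers, and the gap to compound 2 lies beyond the scatter. The two compounds differ in more than one place, so this gap cannot be assigned to any single change.

Compound 3 `NC1=NC2(CCSCC2)N(OCCCOc2ccc(Cl)cc2)C(N)=N1` keeps the core of compound 1 and carries 4-chlorophenyl in place of 3-chlorophenyl on an oxygen on a saturated carbon as its only difference. Among the measured compounds shown here, no measured pair isolates this change, so its size cannot be read from the data. For the measured compounds named here, with compound 1 at 1 nM as the lowest number so far, a move toward higher numbers is the likelier direction. The expected step in this assay is an 8.0-fold higher number from compound 1 to compound 3 (0.90 log units; beyond the scatter) toward weaker inhibition, and an outcome within the scatter is not excluded. In this assay the estimated value for compound 3 is 8 nM (expected range 1.5 nM to 60 nM).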

Compound 3, half-maximal inhibitory concentration: 10 nM
The estimate for compound 3 lay 1.3-fold (0.10 log units) below the measured number; the range from low to high includes it.
By their numbers in this assay, from the lowest: compound 1; then compound 3; then compound 2.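

Among the compounds shown here, with the core of compound 1 and the chain held constant, the exchange of 3-chlorophenyl for 4-chlorophenyl on an oxygen on a saturated carbon gives a 10-fold higher number from compound 1 to compound 3 (1.00 log units; beyond the scatter) in this assay, the first step that can be assigned to a single change. This position therefore responds to which of the two chlorophenyl groups it carries, although they have the same atoms and the same counts of donors and acceptors, and the step is beyond the usual scatter. No measurement at hand gives a reason for this difference.

This single pair does not show whether the step would hold on the core of compound 2, and the gap between compound 2 and the other two compounds remains unassigned, as compound 2 differs from each of them in more than one place. It also leaves open where an unsubstituted phenyl or a pyridine ring on that oxygen would fall relative to compound 1 and compound 3, and how a longer chain would change the numbers.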